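The source may hold more compounds than are shown below. What is called first, only, known or untested is meant among the compounds shown, and "the series" means these compounds.

Measured in a functional assay on PC-3 cells (Homo sapiens) for antiproliferative activity, read by MTT assay, with a stated time of 24 h; a higher number here means a weaker inhibitor, a lower number a stronger inhibitor:

- compound 1 `CCn1c(C(=O)NCCNC(=O)OC(C)(C)C)ccc1C(CC)(CC)c1ccc(OCS(=O)(=O)c2ccccc2)c(C)c1`: > 50000 nM, a limit of the assay
- compound 2 `CCn1c(C(=O)N[C@H](C)C(=O)O)ccc1C(CC)(CC)c1ccc(OCS(=O)(=O)c2ccccc2)c(C)c1`: 20100 nM
- compound 3 `CCn1c(C(=O)N[C@@H](C(=O)O)C(C)C)ccc1C(CC)(CC)c1ccc(OCS(=O)(=O)c2ccccc2)c(C)c1`: 3070 nM

Compound 1 sits at the limit of > 50000 nM in this assay, at which 1 of the 3 values shown sits, so only a limit and no number is known for it. Compound 4 `CCn1c(C(=O)NCCC(=O)O)ccc1C(CC)(CC)c1ccc(OCS(=O)(=O)c2ccccc2)c(C)c1` differs from compound 1 in one place: carboxy in place of (tert-butoxycarbonyl)amino on a saturated chain carbon, two bonds along the chain from an amide-type nitrogen. Within the data shown here, two measured steps bear on this exchange, an at least 2.4-fold lower number from compound 1 to compound 2 (0.39 log units; beyond the scatter) and an at least 16-fold lower number from compound 1 to compound 3 (1.21 log units; beyond the scatter), both replacing the 2-((tert-butoxycarbonyl)amino)ethyl chain with a carboxy-bearing one. The step of a 6.5-fold lower number from compound 2 to compound 3 (0.82 log units; beyond the scatter) shows that isopropyl in place of methyl accounts for much of the larger gain; compound 4 carries no such branch. A modest downward step is therefore expected, an at least 2.5-fold lower number from compound 1 to compound 4 (0.39 log units; beyond the scatter). Compound 4 is estimated at 20000 nM, with a range from 6000 nM to 50000 nM.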

Compound 4, half-maximal inhibitory concentration: 14400 nM
Compound 4: the middle estimate sits 1.4-fold (0.14 log units) above what was measured; the range from low to high includes it.
By their numbers in this assay, from the lowest: compound 3; then compounds 4 and 2 (each within the scatter of the next). At a limit, above all of these: compound 1.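

In this assay, the step of an at least 3.4-fold lower number from compound 1 to compound 4 (0.54 log units; beyond the scatter) shows that carboxy in place of (tert-butoxycarbonyl)amino gives a measurable value on an unbranched chain, without the isopropyl branch of compound 3. The 2-carboxyethyl and 1-carboxyethyl chains are not told apart, with a 1.4-fold lower number from compound 2 to compound 4 (0.14 log units; within the scatter), while a 4.7-fold higher number from compound 3 to compound 4 (0.67 log units; beyond the scatter) leaves the branched chain alone in giving a clear gain. Compound 1 stands at a limit, so its step is a bound only: the limit of > 50000 nM in this assay, at which 1 of the 4 values shown sits.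

Open, as far as these compounds go, is whether an amine in place of carboxy at this chain end would retain the activity. Also open, from the compounds shown here alone, is whether a longer chain carrying the carboxylic acid would give a lower number.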